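The source may hold more compounds than are shown below. What is called first, only, known or untested is meant among the compounds shown, and "the series" means these compounds.

Measured so far:

Compound 1, `CCCCCCSC[C@H](NC(C)=O)C(=O)CCl`, gives 3300 nM in a functional assay on NALM-6 cells (Homo sapiens); on this read-out higher numbers stand for weaker inhibition and lower numbers for stronger inhibition.
Compound 2, `CCCCCCCSC[C@H](NC(C)=O)C(=O)CCl`, gives 4800 nM in this assay.
Compound 3, `CCCCCCCCCCSC[C@H](NC(C)=O)C(=O)CCl`, gives 4700 nM in this assay.

All three share a core in which a sulfur carries a saturated chain of differing length. Compound 2 differs from compound 1 by methyl in place of hydrogen on a saturated chain carbon, six bonds along the chain from a sulfur, and this gave a 1.5-fold higher number from compound 1 to compound 2 (0.16 log units; within the scatter). Compound 3 differs from compound 1 by butyl in place of hydrogen on a saturated chain carbon, six bonds along the chain from a sulfur, with a 1.4-fold higher number from compound 1 to compound 3 (0.15 log units; within the scatter), and compound 3 against compound 2 shows a 1.0-fold lower number from compound 2 to compound 3 (0.01 log units; within the scatter). Across these three compounds, then, the measured numbers sit close together.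

Compound 4, `CCCCCCCCCCCSC[C@H](NC(C)=O)C(=O)CCl`, has not been measured. It differs from compound 3 by methyl in place of hydrogen on a saturated chain carbon, ten or more bonds along the chain from a sulfur. This is the same kind of change as that from compound 1 to compound 2, though it sits at a different place along the chain, as the two descriptions of the changes show. Since compound 1 to compound 2 gave a 1.5-fold higher number from compound 1 to compound 2 (0.16 log units; within the scatter), a step of similar smallness is expected here, namely a 1.1-fold higher number from compound 3 to compound 4 (0.03 log units; within the scatter). Compound 4 is therefore estimated at 5000 nM, with a range from 2500 nM to 10000 nM expected.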

Compound 4, half-maximal inhibitory concentration: 1700 nM
Compound 4: middle estimate off by 2.9-fold (0.47 log units), on the high side; measured number below the stated range.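

Compound 4 breaks from the close grouping of the earlier numbers, with a 2.8-fold lower number from compound 3 to compound 4 (0.44 log units; beyond the scatter), so the methyl change did not repeat on this core what it did on the core of compound 1: the same change on two cores in this assay, a 1.5-fold higher number (0.16 log units; within the scatter) from compound 1 to compound 2 and a 2.8-fold lower number (0.44 log units; beyond the scatter) from compound 3 to compound 4, 4.0-fold (0.60 log units) apart, beyond the scatter of two such steps. The butyl change tells the same story, with a 2.8-fold lower number from compound 2 to compound 4 (0.45 log units; beyond the scatter) set against its earlier step: the same change on two cores in this assay, a 1.4-fold higher number (0.15 log units; within the scatter) from compound 1 to compound 3 and a 2.8-fold lower number (0.45 log units; beyond the scatter) from compound 2 to compound 4, 4.0-fold (0.60 log units) apart, beyond the scatter of two such steps. Compound 4 still stays within the scatter of compound 1, with a 1.9-fold lower number from compound 1 to compound 4 (0.29 log units; within the scatter), so these pairs show that a step measured at one chain length need not carry over to another, but they do not show why, and they do not make compound 4 the strongest of the set.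

From the compounds shown here alone, the whole drop rests on a single compound, and whether a longer chain than that of compound 4 would keep the lower number remains open. Also open, going by these compounds, is what an amine or a carboxylic acid on the chain would do in place of the plain saturated carbons.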